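A few compounds are considered here, and "the series" means these few. Any claim that something is new, unique, unknown or untested is made for them only; others in the source may bear on it.

Values measured in a functional assay on HT-29 cells (Homo sapiens) for inhibition; on this read-out lower numbers stand for stronger inhibition and higher numbers for weaker inhibition:
Compound 1 `CCCCCCCCCCCCCCCCCCOC[C@H](COC(=O)O[C@@H]1[C@H](O)[C@@H](CO)[C@@H](O)[C@H](O)[C@@H]1O)OC`: 12000 nM
Compound 2 `CCCCCCCCCCCCCCCCCCOC[C@H](COC(=O)O[C@@H]1[C@H](O)[C@H](CO)[C@@H](O)[C@H](O)[C@@H]1O)OC`: 10000 nM

Compound 2, at 10000 nM, stands level with compound 1 within the scatter. Going by the values given here, the one measured step, a 1.2-fold lower number from compound 1 to compound 2 (0.08 log units; within the scatter), comes with the fact that compounds 1 and 2 differ only in the configuration as drawn. Compound 3 `CCCCCCCCCCCCCCCCCCOC[C@H](COC(=O)O[C@H]1[C@@H](O)[C@@H](O)[C@H](O)C[C@H]1O)OC` departs from compound 2 by hydrogen in place of hydroxymethyl on a saturated ring carbon. The measured step touches that same ring carbon, but it only changes the configuration there and does not remove the hydroxymethyl, so it is a limited guide. Among the compounds with values here, no measured compound lacks that group. Within the data shown here, with only that step to go on, no shift beyond the scatter is expected, though with wide uncertainty. The expected step is no change at the digits printed from compound 2 to compound 3 (within the scatter). For compound 3 the estimate is 10000 nM, with an expected range from 4000 nM to 25000 nM.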

Compound 3, half-maximal inhibitory concentration: 2500 nM
Beside the measured number, compound 3's estimate is 4.0-fold (0.60 log units) above it; measured number outside the range, below it.
By their numbers in this assay, from the lowest: compound 3; then compounds 2 and 1 (each within the scatter of the next).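

Replacing the hydroxymethyl with hydrogen on this saturated ring carbon does what inverting the configuration there did not: in this assay the number moves beyond the scatter, with a 4.0-fold lower number from compound 2 to compound 3 (0.60 log units; beyond the scatter) and with a 4.8-fold lower number from compound 1 to compound 3 (0.68 log units; beyond the scatter). Inhibition in these cells therefore does not depend on the hydroxymethyl, and its loss gives the lower number from either drawn configuration, though these two starting points amount to nearly one comparison: the fact that compounds 1 and 2 differ only in the configuration as drawn. Of the three compounds, compound 3 alone carries hydrogen on this carbon, and it alone stands apart.

As far as these compounds go, it remains open whether hydrogen itself matters or only the loss of the hydroxymethyl, since a methyl, a fluorine or an aminomethyl on this carbon would tell these apart. From the compounds shown here alone, it is also open whether the same step holds when a shorter chain replaces the long ether chain.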